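From cyano to chloro: estimating compound 4

The compounds below may be only part of what the source reports. "The series", "measured", "known", "first", "only" and "open" are said of these compounds alone.

Values from a functional assay on NALM-6 cells (Homo sapiens) for cytotoxicity, read by luminescence and CellTiter-Glo, with a stated time of 3 days (on this read-out higher numbers stand for weaker inhibition and lower numbers for stronger inhibition), follow.

Compound 1 (`N#Cc1cc(Cl)ccc1NC(=O)c1ccc2cccnc2c1O`) gives 280 nM
Compound 2 (`N#Cc1ccc(NC(=O)c2cc(Br)c3cccnc3c2O)cc1`) gives 210 nM
Compound 3 (`N#Cc1ccc(NC(=O)c2ccc3cccnc3c2O)cc1`) gives 130 nM

Compound 3 stands within the scatter of compound 2, and compound 1 gives a higher number than compound 3. Compound 4 (`O=C(Nc1ccc(Cl)cc1)c1ccc2cccnc2c1O`) has chloro in place of cyano on an aromatic carbon, para to a large group (chloro in place of cyano on an aromatic carbon). Among the compounds with values here, no measured step makes this swap. Within the data shown here, the only step (a 1.6-fold lower number from compound 2 to compound 3 (0.21 log units; within the scatter)) puts hydrogen in place of bromo, so it bears only loosely. Compound 1 carries chloro and cyano together and gives 280 nM without showing what either group does alone. In this assay a modest rise is therefore expected (a 1.5-fold higher number from compound 3 to compound 4 (0.19 log units; within the scatter)) and none beyond the scatter. Compound 4 is estimated at 200 nM (range 70 nM to 550 nM).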

Compound 4, half-maximal inhibitory concentration: 380 nM
Estimate against measurement, compound 4: 1.9-fold (0.28 log units) below, within the range that was stated.
By their numbers in this assay, from the lowest: compounds 3, 2, 1 and 4 (each within the scatter of the next, the first and the last beyond it).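

Putting chloro in place of cyano on this aromatic carbon, para to a large group, gives a step beyond the scatter (a 2.9-fold higher number from compound 3 to compound 4 (0.47 log units; beyond the scatter)) in this assay, so the group at this place can change the result. With chloro at that place, hydrogen in place of cyano on another carbon of the same ring stays within the scatter (a 1.4-fold higher number from compound 1 to compound 4 (0.13 log units; within the scatter)). Nothing available explains either step.

Still open, going by these compounds, is how other groups at this place would compare, such as an amine, a carboxylic acid or a methoxy group. Plain hydrogen there is also untested among the compounds shown.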